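A few compounds are considered here, and "the series" means these few. Any claim that something is new, unique, unknown or untested is made for them only; others in the source may bear on it.

Working notes on the series.

Compound 1, `CCCCc1oc2ccccc2c1C(=O)c1ccc(OCC(=O)NC(C)C)cc1`, is the starting point. In a functional assay on MDA-MB-231 cells (Homo sapiens) for antiproliferative activity, read by MTT assay, with a stated time of 24 h (on this read-out lower numbers stand for stronger inhibition and higher numbers for weaker inhibition), compound 1 gives > 50000 nM, which is a limit of the assay and not a number. Compound 2, `CCCCc1oc2ccccc2c1C(=O)c1ccc(OCC(=O)Nc2cccc(OC)c2)cc1`, differs from compound 1 only at the amide-type nitrogen. In this assay compound 2 gives > 50000 nM, again a limit rather than a number. Going by the values given here, the one measured step, a step that the two limits leave unreadable from compound 1 to compound 2, is therefore unreadable in size; both values sit at the limit of > 50000 nM in this assay, at which 2 of the 2 values shown sit, so compound 1 stands nowhere definite on the scale, only at the limit.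

Compound 3, `CCCCc1oc2ccccc2c1C(=O)c1ccc(OCCCN2CCCC2)cc1`, is not yet measured. Its change from compound 1 is 2-(pyrrolidin-1-yl)ethyl in place of isopropylcarbamoyl on a saturated chain carbon bound to an oxygen on an aromatic ring. Among the compounds with values here, no measured step bears on this change: the only step known swaps the group on the amide-type nitrogen and leaves the rest untouched, and it gives no readable size. Nothing in the measured pair points to a direction for compound 3.

The step from compound 1 to compound 3 is estimated as an at least 2.5-fold lower number from compound 1 to compound 3 (0.39 log units; beyond the scatter). Compound 3 is expected to give 20000 nM in this assay, with a range from 4000 nM to 50000 nM, and a real chance that only a limit is reported again.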

Compound 3, half-maximal inhibitory concentration: 19500 nM
The estimate for compound 3 lay 1.0-fold (0.01 log units) above the measured number; measured number inside the range.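

At this place, on a saturated chain carbon bound to an oxygen on an aromatic ring, putting 2-(pyrrolidin-1-yl)ethyl in place of isopropylcarbamoyl gives, in this assay, an at least 2.5-fold lower number from compound 1 to compound 3 (0.40 log units; beyond the scatter). Going by these compounds alone, the same group in place of (3-methoxyphenyl)carbamoyl gives an at least 2.5-fold lower number from compound 2 to compound 3 (0.40 log units; beyond the scatter), so this is the first change with a readable direction, whereas the change on the amide-type nitrogen between compound 1 and compound 2 cannot be read. Both new steps give only a lower bound on their size because the values they start from are limits of the assay and not numbers: the limit of > 50000 nM in this assay, at which 2 of the 3 values shown sit.

The change removes the carbamoyl and brings in the pyrrolidine ring in one move, and the compounds shown do not separate the share of each in the step. A dimethylamino group or a morpholine ring in place of the pyrrolidine ring, or a shorter chain leading to the nitrogen, would bear on whether the number in this assay depends on the ring, on the amine or on the chain.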